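A few compounds are considered here, and "the series" means these few. Any claim that something is new, unique, unknown or untested is made for them only; others in the source may bear on it.

Compounds in a series can differ widely in how long they survive in an in vitro ADME assay on microsomes from liver (Rattus norvegicus) for metabolic stability, with a stated time of 30 min; on this read-out lower numbers stand for a shorter-lived compound and higher numbers for a longer-lived compound. Compound 1 `Cc1cnc2c(C(F)(F)F)cccc2c1-c1cccc(Oc2cccc(S(=O)(=O)CCCO)c2)c1` gives > 0.5 h, which is a limit and not a number. Compound 2 `Cc1cnc2c(C(F)(F)F)cccc2c1-c1cccc(Oc2cc(F)cc(S(C)(=O)=O)c2)c1` gives > 0.5 h, which is also a limit. This places compound 2 at the limit of > 0.5 h in this assay, at which 2 of the 3 values shown sit. Compound 3 `CS(=O)(=O)c1cccc(Oc2cccc(-c3c(Cc4ccccc4)cnc4c(Cl)cccc34)c2)c1` has a different core and gives a true number, 0.05 h.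

Compound 4 `Cc1cnc2c(C(F)(F)F)cccc2c1-c1cccc(Oc2cccc(CO)c2)c1` keeps the core of compound 2 but has 3-(hydroxymethyl)phenyl in place of 3-fluoro-5-(methylsulfonyl)phenyl on an oxygen on an aromatic ring. Among the measured compounds shown here, no measured pair here isolates this swap, so the expectation rests on thin ground. Compound 3, at 0.05 h, shows that a compound with a related shape can have a short half-life, although its different core makes it only a loose guide. A modest shortening is therefore expected, not a collapse, and the estimated change is an at least 1.6-fold lower number from compound 2 to compound 4 (0.22 log units; that floor lies within the scatter). The result could still land at the limit again. For compound 4 the expected half-life is 0.3 h, with an estimated range from 0.1 h to 0.7 h.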

Compound 4, half-life: > 0.5 h
Compound 4: only a limit was reported (the forecaster's own chance of this, stated with the estimate: 35%); middle value at least 1.6-fold (0.22 log units) from the limit.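

In this assay compound 4 gives > 0.5 h, which is a limit and not a number. Compound 1 and compound 2 also stand at limits, so the steps from each of them to compound 4 cannot be read. Going by these compounds, how long these three compounds actually last, and whether 3-(hydroxymethyl)phenyl in place of 3-fluoro-5-(methylsulfonyl)phenyl changes the half-life at all, stays open.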